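This account rests on a few compounds, and the source may have more. Where it says the series, first, only, none or still open, it means among the compounds named here.

Three compounds that share one core and differ in a single group have been tested in an ADME assay on HepG2 cells (Homo sapiens) for cytotoxicity, with a stated time of 72 h; a higher number here means that more compound is needed for the effect, a lower number that less compound is needed. Compound 1 `Cc1cc(NC(=O)Nc2cccc([N+](=O)[O-])c2)c2ccccc2n1`, which carries nitro, gives only a limit, > 25000 nM. Compound 2 `Cc1cc(NC(=O)Nc2cccc(C(N)=O)c2)c2ccccc2n1`, which carries carbamoyl, also gives only a limit, > 25000 nM. For the measured compounds named here, compound 3 `Cc1cc(NC(=O)Nc2cccc(C(F)(F)F)c2)c2ccccc2n1`, which carries trifluoromethyl, gives 21000 nM, the only actual number in the set. The remaining values both sit at the limit of > 25000 nM in this assay, at which 2 of the 3 values shown sit.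

Compound 4 `Cc1cc(NC(=O)Nc2cccc(N(C)C)c2)c2ccccc2n1` changes that same group: dimethylamino in place of trifluoromethyl on an aromatic carbon, with dimethylamino in place of trifluoromethyl on an aromatic carbon. Two measured swaps at this spot bear on the change: an at least 1.1-fold lower number from compound 1 to compound 3 (0.07 log units; that floor lies within the scatter) and an at least 1.1-fold lower number from compound 2 to compound 3 (0.07 log units; that floor lies within the scatter). Each gives only a minimum size, and that minimum lies within the scatter, so neither shows a large move. A step within the scatter is therefore expected, and compound 4 may also end up reported only as a limit. The estimated change is a 1.1-fold higher number from compound 3 to compound 4 (0.04 log units; within the scatter). For compound 4 the expected value is 23000 nM, with an estimated range from 11000 nM to 45000 nM.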

Compound 4, half-maximal effective concentration: > 25000 nM
Compound 4: a limit, no number; the forecaster's own chance of this, stated with the estimate: 50%; at least 1.0-fold (0.03 log units) between middle value and limit.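

Putting dimethylamino in place of trifluoromethyl at this position gives an at least 1.1-fold higher number from compound 3 to compound 4 (0.07 log units; that floor lies within the scatter) in this assay, so the change can be read only as a minimum size, and that minimum shows no clear move. The steps to compound 4 from compound 1 and from compound 2 join two limits and cannot be read. With a fourth group tested, trifluoromethyl remains the only one at this position to give an actual number, and most of the results now gather at a single point: the limit of > 25000 nM in this assay, at which 3 of the 4 values shown sit.

From the compounds shown here alone, how far compound 1, compound 2 and compound 4 really lie from compound 3 remains open, so the true size of these swaps is unknown. Also open, going by these compounds, is whether a chlorine atom or a longer chain at the same position would give an actual number.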